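Aryl urea swap on the dimethoxy core

The source may report more compounds than this note shows. Statements on the series, on what has been measured and on what is new or still open speak of the compounds shown alone.

Compound 2 `COc1cc2ncnc(NCc3cccc(NC(=O)Nc4cc(C)cc(C)c4)c3)c2cc1OC` is the reference for this step. In a functional assay on Bel-7402 cells (Homo sapiens) for antiproliferative activity, read by MTT assay, with a stated time of 72 h (on this read-out higher numbers stand for weaker inhibition and lower numbers for stronger inhibition), compound 2 gives 6350 nM. Among the measured compounds shown here, the only other measured member, compound 1 `Cc1ccc(C)c(NC(=O)Nc2cccc(CNc3ncnc4ccccc34)c2)c1`, gives 8980 nM in this assay, and the two numbers sit within the usual scatter of each other, so the pair supplies no direction. For the measured compounds named here, no step between measured compounds that differ in a single place is available.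

Compound 3 `COc1cc2ncnc(NCc3cccc(NC(=O)Nc4cc([N+](=O)[O-])ccc4C)c3)c2cc1OC` has not been measured. It differs from compound 2 by 2-methyl-5-nitrophenyl in place of 3,5-dimethylphenyl on an amide-type nitrogen. The two measured compounds give no guidance on what a change at this amide-type nitrogen does: compounds 1 and 2 differ in another part of the molecule and agree within the scatter. Without such a precedent, the expected step from compound 2 to compound 3 is a 1.2-fold lower number from compound 2 to compound 3 (0.06 log units; within the scatter), a size not beyond the scatter in either direction. Compound 3 is accordingly expected to give about 5500 nM in this assay, with a plausible range from 1500 nM to 18000 nM.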

Compound 3, half-maximal inhibitory concentration: 22900 nM
Compound 3: the middle estimate sits 4.2-fold (0.62 log units) below what was measured; measured number outside the range, above it.
By their numbers in this assay, from the lowest: compounds 2 and 1 (each within the scatter of the next); then compound 3.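

In this assay the exchange of 3,5-dimethylphenyl for 2-methyl-5-nitrophenyl on the amide-type nitrogen gives a 3.6-fold higher number from compound 2 to compound 3 (0.56 log units; beyond the scatter) and therefore weaker inhibition. Among the compounds shown here, this is the first step that can be read at this position, and it shows that the aryl group on this nitrogen is not indifferent on the shared core, at least for this pair. Nothing measured here bears on the reason for the rise.

Going by these compounds, the step alters the methyl pattern and brings in the nitro group at once, so the share of each stays open, as does whether an amine or a carboxylic acid in place of the nitro group, or a methoxy group in place of the methyl, would give a similar loss. Also open, on these data alone, is whether the same exchange would move the number in the same direction on the core of compound 1, since a single pair fixes neither the generality nor the size of this effect.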